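Sulfonamide series: ring-opened amino group replacing piperidine

A few compounds are considered here, and "the series" means these few. Any claim that something is new, unique, unknown or untested is made for them only; others in the source may bear on it.

Measured so far in a functional assay on MIA PaCa-2 cells (Homo sapiens) for inhibition, read by MTT assay, with a stated time of 7 days; a lower number here means a stronger inhibitor, a higher number a weaker inhibitor:

Compound 1, `CCOC(=O)[C@@H]1C[C@H](O)CN(S(=O)(=O)c2ccc(S(=O)(=O)N(CC)CC)cc2)C1`, compound 1 gives 1300 nM
Compound 2, `CCOC(=O)[C@@H]1CCCN(S(=O)(=O)c2ccc(S(=O)(=O)N3CCCCC3)cc2)C1`, compound 2 gives 2900 nM
Compound 3, `CCOC(=O)[C@@H]1CCCN(S(=O)(=O)c2ccc(S(=O)(=O)N(CC)CC)c(F)c2)C1`, compound 3 gives 900 nM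

Compound 2 stands at the highest number of the three in this assay; compound 1 sits nearest, compound 3 furthest, and both gaps lie beyond the usual scatter. No pair of these compounds differs in one place only, so no single step is available; compounds 1 and 3 carry open-chain amino groups on the sulfonyl sulfur but also differ from compound 2 elsewhere.

Compound 4, `CCCN(CC)S(=O)(=O)c1ccc(S(=O)(=O)N2CCC[C@@H](C(=O)OCC)C2)cc1`, is not yet measured. Relative to compound 2 the change is ethyl(propyl)amino in place of piperidin-1-yl on a sulfonyl sulfur.

Since compound 1 gives 1300 nM and compound 3 gives 900 nM, both with open-chain amino groups, the step is expected to run toward a lower number, of modest size, as a 1.8-fold lower number from compound 2 to compound 4 (0.26 log units; within the scatter), though it may fall within the scatter. Compound 4 is estimated at 1600 nM, with a range from 700 nM to 3500 nM.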

Compound 4, half-maximal inhibitory concentration: 300 nM
Compound 4: middle estimate off by 5.3-fold (0.73 log units), on the high side, outside the stated range (below it).
By their numbers in this assay, from the lowest: compound 4; then compounds 3 and 1 (each within the scatter of the next); then compound 2.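

In this assay, among these compounds, ethyl(propyl)amino in place of piperidin-1-yl on a sulfonyl sulfur gives a 9.7-fold lower number from compound 2 to compound 4 (0.99 log units; beyond the scatter), the first single-place step in this set and one beyond the scatter. This position on the sulfonyl sulfur therefore responds strongly to the amino group it carries, even though the leaving and entering groups have the same heavy-atom count and neither has hydrogen-bond donors or acceptors; the counted difference is the ring, present in piperidin-1-yl and absent in ethyl(propyl)amino. Nothing shown here accounts for the size of this step.

A single pair cannot show whether the gain comes from opening the ring in general or from this particular pair of chains, and dipropylamino or pyrrolidin-1-yl at the same place would test that. From the compounds shown here alone, it also remains open whether the step carries over to the cores of compound 1 and compound 3.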